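The source may hold more compounds than are shown below. What is called first, only, known or untested is meant among the compounds shown, and "the series" means these compounds.

Working notes on the series. Going by the values given here, in a functional assay on HeLa cells (Homo sapiens) for cytotoxicity, read by MTT assay, with a stated time of 72 h (on this read-out lower numbers stand for stronger inhibition and higher numbers for weaker inhibition), compound 1 (`COc1ccc(/C=C/C(=O)Nc2cc3c(Nc4ccc(F)c(Cl)c4)ncnc3cc2O[C@H]2CCOC2)c(OC)c1OC`) gives 4830 nM and is the only measured compound with a number so far. Compound 2 (`COc1cc(/C=C/C(=O)Nc2cc3c(Nc4ccc(F)c(Cl)c4)ncnc3cc2OC)cc(OC)c1`) offers no starting value: in this assay compound 2 reads "not determined" (no result reported) and so has no position on the potency scale.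

Compound 3 (`COc1cc(/C=C/C(=O)Nc2cc3c(Nc4ccc(F)c(Cl)c4)ncnc3cc2O[C@H]2CCOC2)cc(OC)c1`) derives from compound 2 through a single change, oxolan-3-yl in place of methyl on an oxygen on an aromatic ring and in words, oxolan-3-yl in place of methyl on an oxygen on an aromatic ring. Among the compounds with values here, the same methoxy to (oxolan-3-yl)oxy change has no measured pair behind it, so the series does not show what it does.

In this assay a step within the usual scatter is expected, with no direction favoured. The best available anchor is compound 1, which also carries the (oxolan-3-yl)oxy group and gives 4830 nM in the same test. This is a single value and supports only a weak inference.

For compound 3 the estimated value is 4000 nM with an expected range from 1200 nM to 13000 nM on this basis.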

Compound 3, half-maximal inhibitory concentration: 34300 nM
Compound 3: the middle estimate sits 8.6-fold (0.93 log units) below what was measured; the measured number lies above the stated range.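

In this assay, with the (oxolan-3-yl)oxy group held constant, the aryl group on the double-bonded chain carbon now shows a measured effect: a 7.1-fold higher number from compound 1 to compound 3 (0.85 log units; beyond the scatter) accompanies 3,5-dimethoxyphenyl in place of 2,3,4-trimethoxyphenyl, a step beyond the usual scatter, though it rests on this single pair. The methoxy to (oxolan-3-yl)oxy change on the oxygen on an aromatic ring still cannot be read: compound 2 has no value to set against compound 3, so the result says nothing about that change in either direction. No measurement on hand accounts for the difference between the two methoxy patterns.

Open, going by these compounds, is whether a step of this size between the two aryl patterns would also appear with methoxy in place of (oxolan-3-yl)oxy on the shared core. Also open, on these data alone, is how an unsubstituted phenyl, or a phenyl carrying an amine or a carboxylic acid, would read on the double-bonded chain carbon, and how a longer chain on the aromatic oxygen would compare with oxolan-3-yl.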